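The source may report more compounds than this note shows. Statements on the series, on what has been measured and on what is new or still open speak of the compounds shown alone.

Measured in a functional assay on BXPC-3 cells (Homo sapiens) for antiproliferative activity, read by sulforhodamine B assay, with a stated time of 72 h; on this read-out higher numbers stand for weaker inhibition and lower numbers for stronger inhibition:
- Compound 1 `CC(C)(C)c1[nH]cnc1/C=c1\[nH]c(=O)/c(=C/c2cccc(C(=O)N3CCC3)c2)[nH]c1=O`: > 500 nM (a limit)
- Compound 2 `CC(C)(C)c1[nH]cnc1/C=c1\[nH]c(=O)/c(=C/c2cccc(C(=O)c3cccs3)c2)[nH]c1=O`: 1.72 nM

Among the compounds with values here, compound 2 holds the only true number so far, 1.72 nM. Compound 3 `CC(C)(C)c1[nH]cnc1/C=c1\[nH]c(=O)/c(=C/c2cccc(C(=O)c3ccco3)c2)[nH]c1=O` differs from it in one place: furan-2-yl in place of thiophen-2-yl on a carbonyl carbon. Within the data shown here, the only measured step, an at least 290-fold lower number from compound 1 to compound 2 (2.46 log units; beyond the scatter), is large, but it put thiophen-2-yl in place of azetidin-1-yl, so it bears on this swap only indirectly. The new group is again a five-membered aromatic ring with 1 hetero atom, so a small step is expected, anchored on compound 2 at 1.72 nM. The expected step is a 1.7-fold higher number from compound 2 to compound 3 (0.24 log units; within the scatter), slightly towards a higher number and probably within the scatter. For compound 3 the estimate is 3 nM, with an expected range of 1 nM to 10 nM.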

Compound 3, half-maximal inhibitory concentration: 9.23 nM
Beside the measured number, compound 3's estimate is 3.1-fold (0.49 log units) below it; measured number inside the range.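

In this assay, this carbonyl does not treat two closely matched rings alike: a 5.4-fold higher number from compound 2 to compound 3 (0.73 log units; beyond the scatter) follows from exchanging only the ring's sulfur for oxygen. Furan-2-yl nevertheless remains far better than azetidin-1-yl at this place, with an at least 54-fold lower number from compound 1 to compound 3 (1.73 log units; beyond the scatter) for that change. The value of compound 1 is a limit, so this step gives only a minimum size: the limit of > 500 nM in this assay, at which 1 of the 3 values shown sits.

The values do not explain why the ring's hetero atom matters. As far as these compounds go, how a phenyl or pyridine ring on this carbonyl would compare remains open.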